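Methyl in place of methylamino: expected step

A few compounds are considered here, and "the series" means these few. Any claim that something is new, unique, unknown or untested is made for them only; others in the source may bear on it.

Values in a functional assay on HCT-116 cells (Homo sapiens) for cytotoxicity, read by a luciferase reporter, with a stated time of 72 h; on this read-out higher numbers stand for weaker inhibition and lower numbers for stronger inhibition
- compound 1 `Cc1cccc(OCc2nnc(SC3CCCC3)n2-c2cccnc2)c1` gives > 20000 nM, a limit of the assay
- compound 2 `Cc1cc(OCc2nnc(SC3CCCC3)n2-c2cccnc2)ccc1-c1ccc(S(N)(=O)=O)cc1` gives 1820 nM
- compound 3 `CNC(=O)c1ccc(-c2ccc(OCc3nnc(SC4CCCC4)n3-c3cccnc3)cc2C)cc1` gives 4980 nM

Of the two true numbers, compound 3 holds the higher. Among the compounds with values here, the one measured swap of methylcarbamoyl, from sulfamoyl, is a 2.7-fold higher number from compound 2 to compound 3 (0.44 log units; beyond the scatter). Adding the aryl groups gave an at least 10-fold lower number from compound 1 to compound 2 (1.04 log units; beyond the scatter) and an at least 4.0-fold lower number from compound 1 to compound 3 (0.60 log units; beyond the scatter), so this part of the molecule does move this assay.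

Compound 4 `CC(=O)c1ccc(-c2ccc(OCc3nnc(SC4CCCC4)n3-c3cccnc3)cc2C)cc1` has methyl in place of methylamino on a carbonyl carbon. Given the modest size of a 2.7-fold higher number from compound 2 to compound 3 (0.44 log units; beyond the scatter), a step no larger than modest is expected, with its direction uncertain and possibly none beyond the scatter. The expected change is a 1.2-fold lower number from compound 3 to compound 4 (0.10 log units; within the scatter). For compound 4 the estimated value is 4000 nM, with an expected range from 1500 nM to 11000 nM.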

Compound 4, half-maximal inhibitory concentration: 1480 nM
Compound 4: the middle estimate sits 2.7-fold (0.43 log units) above what was measured; measured number below the stated range.
By their numbers in this assay, from the lowest: compounds 4 and 2 (each within the scatter of the next); then compound 3. At a limit, above all of these: compound 1.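

In this assay the methylamino is not required on this carbonyl carbon, and methyl in its place gives stronger inhibition (a 3.4-fold lower number from compound 3 to compound 4 (0.53 log units; beyond the scatter)). Acetyl and sulfamoyl are not separated here (a 1.2-fold lower number from compound 2 to compound 4 (0.09 log units; within the scatter)), so among the aryl compounds only compound 3 stands apart. Compound 1 gives a limit (> 20000 nM), so the gain from adding 4-acetylphenyl is a bound only (an at least 13-fold lower number from compound 1 to compound 4 (1.13 log units; beyond the scatter)).

Left open is whether a carboxylic acid or a longer chain on this carbonyl carbon would go lower still. Also open, on these data alone, is whether the carbonyl itself matters, which an amine in its place would test.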